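A few compounds are considered here, and "the series" means these few. Any claim that something is new, unique, unknown or untested is made for them only; others in the source may bear on it.

Working notes on the quinoline sulfone series, all read in an assay on isolated protein for displacement of a labelled ligand from metabotropic glutamate receptor 5 (Homo sapiens), with a stated time of 60 min, tested at 1 uM; on this read-out lower numbers stand for less inhibition and higher numbers for more inhibition at the one concentration tested (going by the name of the read-out).

For the measured compounds named here, compound 3 `Cc1ccc2ncc(S(=O)(=O)c3ccc(F)cc3)c(N3CCC(C)CC3)c2c1` gives 90% and stands second highest of the three numbers so far. Compound 1 `CC1CCN(c2c(S(=O)(=O)c3ccc(Cl)cc3)cnc3cc(Cl)ccc23)CC1` gives 91%, within the scatter of compound 3, so no order between the two is claimed. Compound 2 `COc1ccc2ncc(S(=O)(=O)c3ccc(OC)c(Cl)c3)c(N3CCC(C)CC3)c2c1` gives 21%, well beyond the scatter below compound 3.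

Compound 4 `Cc1ccc2ncc(S(=O)(=O)c3ccc(C#N)cc3)c(N3CCC(C)CC3)c2c1` is not yet measured. It differs from compound 3 by cyano in place of fluoro on an aromatic carbon. Going by the values given here, no measured pair shows this change, so its size is open. Because compound 3 gives 90% and the change keeps the rest of the structure, the expectation is a modest downward step in this assay, near the edge of the scatter, not a collapse. Compound 4 is estimated at 75%, range 40% to 95%, meaning an expected step of a number 15 percentage points lower from compound 3 to compound 4 (beyond the scatter).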

Compound 4, a percentage reported as inhibition, at one concentration (the size of the read-out at that concentration, not a potency): 55%
For compound 4 the middle estimate is 20 percentage points above the measured one; measured number inside the range.
By their numbers in this assay, from the lowest: compound 2; then compound 4; then compounds 3 and 1 (each within the scatter of the next).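

For the compounds shown here, replacing fluoro with cyano on this aromatic carbon, para to a large group, gives in this assay a number 35 percentage points lower from compound 3 to compound 4 (beyond the scatter), the first single-place change, and shows that the read-out is sensitive to the group at this position. Even so, compound 4 retains 55% in this assay, so inhibition falls without being lost. Nothing at hand explains the step.

From the compounds shown here alone, whether a plain hydrogen, an amine or a carboxylic acid at this position would fall closer to fluoro or to cyano remains open. Also open, going by these compounds, is whether the same change would give a similar step on the core of compound 1.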